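A triazole isomer swap on the shared core

The source may hold more compounds than are shown below. What is called first, only, known or untested is meant among the compounds shown, and "the series" means these compounds.

In a functional assay on the whole organism for inhibition, with Rattus norvegicus as the target, read by paw edema (on this read-out lower numbers stand for an effect already at smaller amounts and higher numbers for an effect only at larger amounts of compound), compound 1 (`O=C(O)c1cc(-c2cocn2)ccc1O`) gives 110 mg/kg and compound 2 (`O=C(O)c1cc(-n2cncn2)ccc1O`) gives 200 mg/kg. Going by the values given here, these are the only two measurements so far, so compound 2 has a single neighbour on the scale, and the two values lie within the scatter of each other.

Compound 3 (`O=C(O)c1cc(-n2cnnc2)ccc1O`) has not yet been measured. It differs from compound 2 only in how the triazole is attached: 4H-1,2,4-triazol-4-yl in place of 1H-1,2,4-triazol-1-yl on an aromatic carbon. The place stays the same, meta to a carboxy group and para to a hydroxy group.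

Among the compounds with values here, one measured step bears on this place: a 1.8-fold higher number from compound 1 to compound 2 (0.26 log units; within the scatter). There, 1H-1,2,4-triazol-1-yl replaced 1,3-oxazol-4-yl and the number stayed within the scatter. Within the data shown here, no measured pair compares the two triazole attachments directly, so the expectation rests on that single step and on the value of compound 2, with a wide margin. The estimated change is a 1.1-fold lower number from compound 2 to compound 3 (0.05 log units; within the scatter), and no step beyond the scatter is expected in this assay, in either direction. Compound 3 is expected at 180 mg/kg, with an estimated range of 90 mg/kg to 360 mg/kg.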

Compound 3, dose for half-maximal effect: > 250 mg/kg
Compound 3: no number, only a limit; the forecaster's own chance of this, stated with the estimate: 5%; middle value at least 1.3-fold (0.14 log units) from the limit.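

Compound 3 gives a limit of the assay and not a number in this assay: the limit of > 250 mg/kg in this assay, at which 1 of the 3 values shown sits.

The place meta to a carboxy group and para to a hydroxy group now shows its first step beyond the scatter, with 4H-1,2,4-triazol-4-yl in place of 1,3-oxazol-4-yl giving an at least 2.2-fold higher number from compound 1 to compound 3 (0.35 log units; beyond the scatter). The swap between the two triazole attachments, which keeps the same atoms joined differently, gives an at least 1.2-fold higher number from compound 2 to compound 3 (0.09 log units; that floor lies within the scatter), so this floor does not by itself separate the two attachments, although the series now shows that this place can tolerate a change of ring and still move the read-out past the scatter.

Going by these compounds, the true size of the step from the 1H-1,2,4-triazol-1-yl to the 4H-1,2,4-triazol-4-yl attachment stays open, since only its floor can be read. Also open is how a non-ring substituent at the same place, such as an amine, a carboxylic acid or a longer alkyl chain, would read in this assay against the three five-membered aromatic rings shown here.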